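The compounds below may be only part of what the source reports. "The series", "measured", "known", "first", "only" and "open" are said of these compounds alone.

Compound 1 `COc1cc(CC(O)c2ccc(-c3ccc(C#N)cc3)cc2)c([N+](=O)[O-])cc1OC` sits in a small series built on a shared core, with the aryl group varied on an aromatic carbon. In an ADME assay on HeLa Rh cells (Homo sapiens) for cytotoxicity, read by microscopy (on this read-out higher numbers stand for lower toxicity in this test and lower numbers for higher toxicity in this test), compound 1 gives 4700 nM, the lowest of the two numbers recorded so far. Among the compounds with values here, the only comparison is compound 2 `COc1cc(CC(O)c2ccc(-c3cccc(F)c3)cc2)c([N+](=O)[O-])cc1OC`, which in this assay gives 7400 nM; the step of a 1.6-fold higher number from compound 1 to compound 2 (0.20 log units; within the scatter) is within the scatter, so the two compounds are not distinguished on this read-out.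

Compound 3 `COc1cc(CC(O)c2ccc(-c3cccc([N+](=O)[O-])c3)cc2)c([N+](=O)[O-])cc1OC` is not yet measured. Its change from compound 1 is 3-nitrophenyl in place of 4-cyanophenyl on an aromatic carbon. Within the data shown here, the one step that bears on this position, the change from compound 1 to compound 2, stayed within the scatter, so no step beyond the scatter is expected here either. For compound 3 the expected step is a 1.2-fold higher number from compound 1 to compound 3 (0.07 log units; within the scatter). Compound 3 is therefore estimated at 5500 nM in this assay, within a range of 2500 nM to 12000 nM.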

Compound 3, half-maximal cytotoxic concentration: 5500 nM
Compound 3: middle estimate and measured number agree at the digits printed; measured number inside the range.
By their numbers in this assay, from the lowest: compounds 1, 3 and 2 (each within the scatter of the next).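

The third aryl group at this position leaves the read-out in this assay unresolved: 3-nitrophenyl in place of 4-cyanophenyl gives a step within the scatter (a 1.2-fold higher number from compound 1 to compound 3 (0.07 log units; within the scatter)). Compound 3 also supplies a comparison the earlier pair lacked, with nitro in place of fluoro at the same named ring position of the aryl group (a 1.3-fold lower number from compound 2 to compound 3 (0.13 log units; within the scatter)). All three compounds therefore remain undistinguished in this test, and no measurement here offers an explanation for how closely they agree.

The 4-cyanophenyl and 3-nitrophenyl names differ in both substituent and ring position, so the two changes cannot be separated in this pair. As far as these compounds go, whether an amine, a carboxylic acid or an unsubstituted phenyl at this position would give a step beyond the scatter remains open.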